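The compounds below may be only part of what the source reports. "The series", "measured", "known", "first", "only" and "open" are said of these compounds alone.

Within the data shown here, compound 1 `C=C1C(=O)O[C@H]2CC3=C[C@H](C/C(C)=C/[C@@H](OC(=O)c4ccc(C(C)=O)cc4)[C@H]12)OC3=O` is the one compound of this set with an actual number in a functional assay on A549 cells (Homo sapiens) for cytotoxicity, read by MTT assay, with a stated time of 48 h (a lower number here means a stronger inhibitor, a higher number a weaker inhibitor), where compound 1 gives 2300 nM. Compound 2 `C=C1C(=O)O[C@H]2CC3=C[C@H](C/C(C)=C/[C@@H](OC(=O)/C=C/c4ccc(N(C)C)cc4)[C@H]12)OC3=O` carries 2-(4-(dimethylamino)phenyl)ethenyl in place of 4-acetylphenyl on the carbonyl carbon; in this assay compound 2 reaches only the limit > 10000 nM. That step was an at least 4.3-fold higher number from compound 1 to compound 2 (0.63 log units; beyond the scatter), which reflects (the limit of > 10000 nM in this assay, at which 1 of the 2 values shown sits). Compound 3 `C=C1C(=O)O[C@H]2CC3=C[C@H](C/C(C)=C/[C@@H](OC(=O)/C=C/c4ccncc4)[C@H]12)OC3=O` differs from compound 1 by 2-(pyridin-4-yl)ethenyl in place of 4-acetylphenyl on a carbonyl carbon. Among the measured compounds shown here, since the only measured step of this kind weakened the compound, a weakening is expected here too: compound 3 is estimated at 6000 nM, between 2500 nM and 15000 nM. That expected step is a 2.6-fold higher number from compound 1 to compound 3 (0.42 log units; beyond the scatter).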

Compound 3, half-maximal inhibitory concentration: 4000 nM
For compound 3 the middle estimate is 1.5-fold (0.18 log units) above the measured one, within the range that was stated.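

In this assay the change from 4-acetylphenyl to 2-(pyridin-4-yl)ethenyl gives a 1.7-fold higher number from compound 1 to compound 3 (0.24 log units; within the scatter) and so separates nothing: this place on the carbonyl carbon takes both groups. With the ethenyl chain kept, pyridin-4-yl in place of 4-(dimethylamino)phenyl gives an at least 2.5-fold lower number from compound 2 to compound 3 (0.39 log units; beyond the scatter) and shows that the ethenyl chain alone does not carry the weakening seen with compound 2. That second step starts from a limit, not a number: the limit of > 10000 nM in this assay, at which 1 of the 3 values shown sits.

Open, as far as these compounds go, is how a plain phenyl or a 4-aminophenyl on the same ethenyl chain would compare, and so whether the ring nitrogen of compound 3 or the dimethylamino group of compound 2 decides the difference.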